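The compounds below may be only part of what the source reports. "The series", "measured", "known", "first", "only" and "open" are said of these compounds alone.

Measured in a functional assay on Bel-7402 cells (Homo sapiens) for antiproliferative activity, read by MTT assay, with a stated time of 72 h; on this read-out lower numbers stand for stronger inhibition and higher numbers for weaker inhibition:
- compound 1 `C=C1C(=O)O[C@H]2[C@H]1CC/C(Cn1cc(Cn3cc(F)c(=O)[nH]c3=O)nn1)=C\CC[C@@]1(C)O[C@@H]21` (> 20000 nM, a limit and not a number)
- compound 2 `C=C1C(=O)O[C@H]2[C@H]1CC/C(Cn1cc(Cn3cc(F)c(=O)n(Cc4ccc(F)cc4)c3=O)nn1)=C\CC[C@@]1(C)O[C@@H]21` (4910 nM)
- compound 3 `C=C1C(=O)O[C@H]2[C@H]1CC/C(COC(=O)Cn1cc(F)c(=O)n(Cc3ccccc3F)c1=O)=C\CC[C@@]1(C)O[C@@H]21` (3770 nM)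

Compound 3 (3770 nM) and compound 2 (4910 nM) lie within the scatter of each other. Compound 1 stands apart as a limit (the limit of > 20000 nM in this assay, at which 1 of the 3 values shown sits).

Compound 4 `C=C1C(=O)O[C@H]2[C@H]1CC/C(COC(=O)Cn1cc(F)c(=O)n(CCC)c1=O)=C\CC[C@@]1(C)O[C@@H]21` has not been measured. It differs from compound 3 by ethyl in place of 2-fluorophenyl on a saturated chain carbon bound to an aromatic nitrogen (ethyl in place of 2-fluorophenyl on a saturated chain carbon bound to an aromatic nitrogen, or 2-fluorobenzyl to propyl when cut one bond further out).

For the measured compounds named here, one measured step touches a group on that aromatic nitrogen: an at least 4.0-fold lower number from compound 1 to compound 2 (0.60 log units; beyond the scatter) (4-fluorobenzyl in place of hydrogen). It lies beyond the scatter, but it bears only loosely on this change. Compound 4 keeps a chain on the nitrogen, unlike compound 1 (> 20000 nM), and compounds 1 and 2 are joined to the shared core differently from compound 3. Going by the values given here, no measured step replaces a benzyl group with a plain chain. In this assay a small move towards a higher number is therefore expected, smaller than the step from hydrogen and possibly within the scatter.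

The expected step is a 1.6-fold higher number from compound 3 to compound 4 (0.20 log units; within the scatter) as estimated here.

For compound 4 the estimated value is 6000 nM (expected range 2500 nM to 16000 nM).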

Compound 4, half-maximal inhibitory concentration: 8580 nM
Beside the measured number, compound 4's estimate is 1.4-fold (0.16 log units) below it; the range from low to high includes it.
By their numbers in this assay, from the lowest: compounds 3, 2 and 4 (each within the scatter of the next, the first and the last beyond it). At a limit, above all of these: compound 1.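

In this assay, ethyl in place of 2-fluorophenyl on a saturated chain carbon bound to an aromatic nitrogen gives a 2.3-fold higher number from compound 3 to compound 4 (0.36 log units; beyond the scatter). The earlier step only set hydrogen against 4-fluorobenzyl, whereas this one compares two groups on the nitrogen, and it shows that the identity of the group matters, modestly, with compound 4 still giving a measured number of 8580 nM while carrying propyl and no ring at this place. Compound 1, with hydrogen on that nitrogen and a different link to the shared core, remains a limit and not a number: the limit of > 20000 nM in this assay, at which 1 of the 4 values shown sits.

From the compounds shown here alone, what a plain benzyl would give on this nitrogen stays open, so the contributions of the ring and of the fluorine to the step cannot be told apart. Also open, going by these compounds, is how a butyl chain, or a chain ending in an amine or a carboxylic acid, would read here, and whether hydrogen on this nitrogen would give a limit with the link to the shared core found in compound 3.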